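Methoxy to ethoxy on compound 2

The source may hold more compounds than are shown below. What is called first, only, known or untested is meant among the compounds shown, and "the series" means these compounds.

In a functional assay on Jurkat cells (Homo sapiens) for antiproliferative activity, read by MTT assay, with a stated time of 72 h (on this read-out higher numbers stand for weaker inhibition and lower numbers for stronger inhibition), compound 1 (`CCOc1ccc(-c2sc(NC)nc2-c2cc(OC)c(OC)c(OC)c2)cc1`) gives 1.7 nM and compound 2 (`COc1ccc(-c2sc(C)nc2-c2cc(OC)c(OC)c(OC)c2)cc1`) gives 1760 nM, the higher of the two numbers and beyond the scatter. Compound 3 (`CCOc1ccc(-c2sc(C)nc2-c2cc(OC)c(OC)c(OC)c2)cc1`) follows from compound 2 by methyl in place of hydrogen on a saturated chain carbon bound to an oxygen on an aromatic ring: methyl in place of hydrogen, turning 4-methoxyphenyl into 4-ethoxyphenyl. Going by the values given here, no measured pair shows this change alone. Compound 1, which also holds 4-ethoxyphenyl, reaches 1.7 nM, so a moderate step towards stronger inhibition, beyond the scatter, is expected in this assay. The estimated step is a 5.9-fold lower number from compound 2 to compound 3 (0.77 log units; beyond the scatter). Compound 3 is expected at 300 nM, with an estimated range of 40 nM to 1500 nM.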

Compound 3, half-maximal inhibitory concentration: 1740 nM
The estimate for compound 3 lay 5.8-fold (0.76 log units) below the measured number; the measured number lies above the stated range.
By their numbers in this assay, from the lowest: compound 1; then compounds 3 and 2 (each within the scatter of the next).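

In this assay, methoxy to ethoxy on the methyl-bearing core gives a 1.0-fold lower number from compound 2 to compound 3 (0.00 log units; within the scatter), so 4-ethoxyphenyl alone does not bring the strong inhibition seen with compound 1. The large difference lies at the other place, methyl in place of methylamino on an aromatic carbon, with a 1000-fold higher number from compound 1 to compound 3 (3.01 log units; beyond the scatter) as the step. Nothing available gives a reason for either step.

Still open, from the compounds shown here alone, is whether 4-methoxyphenyl and 4-ethoxyphenyl also match when methylamino is present. Going by these compounds, how a primary amine or ethylamino at that aromatic carbon would compare also remains open.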